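The compounds below may be only part of what the source reports. "The series", "measured", "known", "first", "only" and "open" are said of these compounds alone.

Measured so far in a functional assay on HeLa cells (Homo sapiens) for cytotoxicity, read by MTT assay; a lower number here means a stronger inhibitor, a higher number a weaker inhibitor:

- Compound 1 `CC(C)=CC[C@@H](OC(=O)CC(C)(O)C(C)C)C1=CC(=O)c2c(O)ccc(O)c2C1=O`: 27700 nM
- Compound 2 `CC(C)=CC[C@@H](OC(=O)C1CCCO1)C1=CC(=O)c2c(O)ccc(O)c2C1=O`: 17000 nM

Among the compounds with values here, compound 2 stands within the scatter of compound 1, so these two values set no order between the compounds. The next compound is compound 3 `CCC(C)(O)CC(=O)O[C@H](CC=C(C)C)C1=CC(=O)c2c(O)ccc(O)c2C1=O`, and the change from compound 2 is 2-hydroxy-2-methylbutyl in place of oxolan-2-yl on a carbonyl carbon. In words, this is 2-hydroxy-2-methylbutyl in place of oxolan-2-yl on a carbonyl carbon.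

Within the data shown here, only one measured step bears on this change: a 1.6-fold lower number from compound 1 to compound 2 (0.21 log units; within the scatter). That step involves the same oxolan-2-yl at the same place, with 2-hydroxy-2,3-dimethylbutyl as the other group. The entering 2-hydroxy-2-methylbutyl is closest by name to that group of compound 1, which gives 27700 nM. A single step within the scatter is thin evidence, but it gives no reason to expect a change of any size or direction beyond the scatter in this assay.

The expected size of the change is a 1.3-fold higher number from compound 2 to compound 3 (0.11 log units; within the scatter). The estimate for compound 3 is 22000 nM, with an expected range of 11000 nM to 42000 nM.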

Compound 3, half-maximal inhibitory concentration: 25200 nM
Compound 3: the middle estimate sits 1.1-fold (0.06 log units) below what was measured; the range from low to high includes it.
By their numbers in this assay, from the lowest: compounds 2, 3 and 1 (each within the scatter of the next).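

In this assay, the swap on a carbonyl carbon from a ring with no hydrogen-bond donor, oxolan-2-yl, to an open chain with one, 2-hydroxy-2-methylbutyl, gives a 1.5-fold higher number from compound 2 to compound 3 (0.17 log units; within the scatter), so neither the loss of the ring nor the added donor separates these two compounds. Inside the open chain, hydrogen in place of methyl on a saturated chain carbon bound to two saturated chain carbons gives a 1.1-fold lower number from compound 1 to compound 3 (0.04 log units; within the scatter), a second kind of change at this position that also sets no order, and all three compounds now sit within the scatter of one another along the printed sequence. Nothing measured here explains this closeness, and no cause can be given for it.

From the compounds shown here alone, whether any group on this carbonyl carbon can move the number beyond the scatter stays open; an amine, a carboxylic acid or a phenyl ring in that place would test it. Going by these compounds, whether the hydroxy group of the open chains counts for anything also stays open, and a plain butyl chain in its place would speak to that.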